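Imide cyclopropane substitution in a deubiquitinase inhibitor series

A few compounds are considered here, and "the series" means these few. Any claim that something is new, unique, unknown or untested is made for them only; others in the source may bear on it.

Measured compounds:
compound 1 `Cc1cc(Cl)cc(-c2ccnc3cc(CN4C(=O)C5CC5C4=O)sc23)c1C[C@H]1OCCN[C@@H]1C`, 210 nM
compound 2 `Cc1cc(Cl)cc(-c2ccnc3cc(CN4C(=O)C5CC5C4=O)sc23)c1C[C@@H]1CNCCO1`, 35 nM
compound 3 `Cc1cc(Cl)cc(-c2ccnc3cc(CN4C(=O)C5C(C4=O)C5(C)C)sc23)c1O[C@@H]1CCNC[C@@H]1C`, 65 nM

Compound 3 stands second highest of the three numbers in an assay on RKO cells for inhibition of ubiquitin carboxyl-terminal hydrolase 7 (Homo sapiens), read by a luciferase reporter, with a stated time of 18 h; a lower number here means that less compound is needed, a higher number that more compound is needed for the effect; its nearest neighbour is compound 2, a gap within the scatter, and its furthest is compound 1, a gap beyond the scatter.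

Compound 4 `Cc1cc(Cl)cc(-c2ccnc3cc(CN4C(=O)C5CC5C4=O)sc23)c1O[C@@H]1CCNC[C@@H]1C` differs from compound 3 by a group of 8 heavy atoms (5 carbon, 1 nitrogen, 2 oxygen; one three-membered non-aromatic ring of carbon only, one five-membered non-aromatic ring with 1 hetero atom) in place of a group of 10 heavy atoms (7 carbon, 1 nitrogen, 2 oxygen; one three-membered non-aromatic ring of carbon only, one five-membered non-aromatic ring with 1 hetero atom), on a saturated chain carbon bound to an aromatic carbon. Going by the values given here, the only measured step, a 6.0-fold lower number from compound 1 to compound 2 (0.78 log units; beyond the scatter), concerns hydrogen in place of methyl on a saturated ring carbon elsewhere in the shared core and does not touch the part altered here, so no measured step bears directly on the change from compound 3 to compound 4. Compounds 1 and 2 carry the same entering group as compound 4, but each also differs from compound 3 in a second place, so their values give only indirect guidance. Among the compounds with values here, with no direct precedent, the step is expected to fall within the scatter, and the estimate for compound 4 is 55 nM (range 20 nM to 160 nM), corresponding to an expected step of a 1.2-fold lower number from compound 3 to compound 4 (0.07 log units; within the scatter).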

Compound 4, half-maximal effective concentration: 170 nM
Compound 4: middle estimate off by 3.1-fold (0.49 log units), on the low side; the whole stated range lies below it.
By their numbers in this assay, from the lowest: compounds 2 and 3 (each within the scatter of the next); then compounds 4 and 1 (each within the scatter of the next).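

In this assay, going by these compounds alone, the group on the saturated chain carbon bound to an aromatic carbon matters: the group of 8 heavy atoms in place of the group of 10 heavy atoms gives a 2.6-fold higher number from compound 3 to compound 4 (0.42 log units; beyond the scatter), the first measured step at this place. With that group of 8 heavy atoms held constant, (3-methylpiperidin-4-yl)oxy in place of (morpholin-2-yl)methyl gives a 4.9-fold higher number from compound 2 to compound 4 (0.69 log units; beyond the scatter), beyond the scatter, while in place of (3-methylmorpholin-2-yl)methyl it gives a 1.2-fold lower number from compound 1 to compound 4 (0.09 log units; within the scatter), within the scatter. No supporting data bear on the origin of these steps.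

On these data alone, whether the step from the group of 8 heavy atoms to the group of 10 heavy atoms carries over to compounds with (morpholin-2-yl)methyl remains open. Also open, as far as these compounds go, is how a single methyl or two fluorines on the three-membered ring would read at this place.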